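Estimating Compound 4 after the Trifluoromethyl-to-Butyl Change

The source may report more compounds than this note shows. Statements on the series, on what has been measured and on what is new or still open speak of the compounds shown alone.

Compound 1 `CC1CC/C(=N\Nc2ccc(F)cc2)c2ncc(C(=O)O)c(=O)n21`: 12.2 umol/kg
Compound 2 `CCOc1ccc(N/N=C2\CCC(C)n3c2ncc(C(=O)O)c3=O)cc1`: 1.6 umol/kg
Compound 3 `CC1CC/C(=N\Nc2ccc(C(F)(F)F)cc2)c2ncc(C(=O)O)c(=O)n21`: 38.6 umol/kg

In a functional assay on the whole organism for inhibition, with Rattus norvegicus as the target (on this read-out lower numbers stand for an effect already at smaller amounts and higher numbers for an effect only at larger amounts of compound), compound 3 gives the highest of the three numbers; compound 1 comes nearest with a 3.2-fold higher number from compound 1 to compound 3 (0.50 log units; beyond the scatter), and compound 2 lies furthest with a 24-fold higher number from compound 2 to compound 3 (1.38 log units; beyond the scatter). Compound 4 `CCCCc1ccc(N/N=C2\CCC(C)n3c2ncc(C(=O)O)c3=O)cc1` differs from compound 3 by butyl in place of trifluoromethyl on an aromatic carbon. For the measured compounds named here, no measured step puts a butyl group at this carbon, so the bearing steps are indirect: leaving trifluoromethyl for fluoro gave a modest drop, and for ethoxy the large one already noted. Compound 4 is therefore expected to give a lower number than compound 3, by a 4.8-fold lower number from compound 3 to compound 4 (0.68 log units; beyond the scatter), though with wide uncertainty. The estimate for compound 4 is 8 umol/kg, expected to fall between 2 umol/kg and 30 umol/kg.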

Compound 4, dose for 50% inhibition: 7.8 umol/kg
Compound 4: middle estimate off by 1.0-fold (0.01 log units), on the high side, and the stated range covers the measured number.
By their numbers in this assay, from the lowest: compound 2; then compounds 4 and 1 (each within the scatter of the next); then compound 3.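

In this assay, trifluoromethyl and butyl carry the same number of heavy atoms, yet exchanging them at this carbon still moves the result: a 4.9-fold lower number from compound 3 to compound 4 (0.69 log units; beyond the scatter). Butyl cannot be told apart from fluoro, with a 1.6-fold lower number from compound 1 to compound 4 (0.19 log units; within the scatter), whereas ethoxy keeps a clear lead over butyl, with a 4.9-fold higher number from compound 2 to compound 4 (0.69 log units; beyond the scatter). Nothing available explains these differences.

The compounds shown leave open how a propyl or hexyl chain would compare with butyl. They also leave open whether a methoxy group or an amine at this carbon would match ethoxy.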